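A few compounds are considered here, and "the series" means these few. Any claim that something is new, unique, unknown or untested is made for them only; others in the source may bear on it.

Within the data shown here, compound 1 `c1cc(OCCCc2nnn[nH]2)cc(OCc2ccc3ccccc3n2)c1` holds the lower of the two numbers known in a functional assay (lung) for inhibition, with Cavia porcellus as the target; on this read-out lower numbers stand for stronger inhibition and higher numbers for weaker inhibition: compound 1 gives 79 nM, while compound 2 `CC(CCCc1nnn[nH]1)c1cccc(OCc2ccc3ccccc3n2)c1` gives 250 nM, a gap beyond the usual scatter. Compound 3 `CC(Cc1cccc(OCc2ccc3ccccc3n2)c1)CC(C)C(=O)O` has not yet been measured. It differs from compound 1 in one place (4-carboxy-2-methylpentyl in place of 3-(1H-tetrazol-5-yl)propoxy on an aromatic carbon). Among the measured compounds shown here, no measured pair shows this exact change, so its size is open. For the measured compounds named here, the only other change to this part of the core, in compound 2, raised the number. A modest weakening is therefore expected, a 2.0-fold higher number from compound 1 to compound 3 (0.31 log units; beyond the scatter). For compound 3 the estimate is 160 nM, ranging from 40 nM to 650 nM.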

Compound 3, half-maximal inhibitory concentration: 500 nM
Beside the measured number, compound 3's estimate is 3.1-fold (0.49 log units) below it; the range from low to high includes it.
By their numbers in this assay, from the lowest: compound 1; then compounds 2 and 3 (each within the scatter of the next).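

In this assay, the position on the aromatic carbon still gives a measurable number when the tetrazole ring is replaced by a chain with no ring, but 4-carboxy-2-methylpentyl in place of 3-(1H-tetrazol-5-yl)propoxy brings a 6.3-fold higher number from compound 1 to compound 3 (0.80 log units; beyond the scatter) as a clear loss. This single swap alters the end group, the chain and its methyl branch together, and nothing available explains the size of the step. Still open, as far as these compounds go, is how a 3-carboxypropoxy chain, which would change only the end group of compound 1, or an amide at that end would read.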